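The compounds below may be only part of what the source reports. "The series", "measured", "known", "first", "only" and "open" are said of these compounds alone.

Compound 1 `CCCN(CCC)c1nc(C(C)(C)C)ccc1CNC(=O)C(C)c1ccc(NS(C)(=O)=O)c(F)c1` gives 2.5 nM in an assay on cells for antagonist activity at transient receptor potential cation channel subfamily V member 1 (Homo sapiens), read by FLIPR and calcium flux, with a stated time of 6 min (a lower number here means a stronger inhibitor, a higher number a weaker inhibitor), the second highest of the three numbers shown. Compound 2 `CCCCOc1nc(C(C)(C)C)ccc1CNC(=O)C(C)c1ccc(NS(C)(=O)=O)c(F)c1` gives 0.9 nM in this assay, and compound 3 `CCCCCCOc1nc(C(C)(C)C)ccc1CNC(=O)C(C)c1ccc(NS(C)(=O)=O)c(F)c1` gives 2.7 nM. The move from compound 1 to compound 2 is a 2.8-fold lower number from compound 1 to compound 2 (0.44 log units; beyond the scatter), whereas the move from compound 1 to compound 3 is a 1.1-fold higher number from compound 1 to compound 3 (0.03 log units; within the scatter); between the two ethers, the move from compound 2 to compound 3 is a 3.0-fold higher number from compound 2 to compound 3 (0.48 log units; beyond the scatter).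

Compound 4 `CCCCCCSc1nc(C(C)(C)C)ccc1CNC(=O)C(C)c1ccc(NS(C)(=O)=O)c(F)c1` differs from compound 1 by hexylsulfanyl in place of dipropylamino on an aromatic carbon. Within the data shown here, the step that bears most directly is the one from compound 1 to compound 3, where a chain of the same length on an oxygen left the number unchanged within the scatter, while the shorter chain of compound 2 gave a modest gain. A hexyl chain on sulfur is therefore expected to land close to compound 1, with a 1.2-fold higher number from compound 1 to compound 4 (0.08 log units; within the scatter) as the expected step. Compound 4 is estimated at 3 nM in this assay, within a range of 1 nM to 9 nM.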

Compound 4, inhibition constant: 1.5 nM
Estimate against measurement, compound 4: 2.0-fold (0.30 log units) above, within the range that was stated.
By their numbers in this assay, from the lowest: compounds 2, 4, 1 and 3 (each within the scatter of the next, the first and the last beyond it).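

In this assay the hexylsulfanyl group of compound 4 cannot be told apart from any of the three groups seen earlier on this aromatic carbon: dipropylamino (a 1.7-fold lower number from compound 1 to compound 4 (0.22 log units; within the scatter)), hexyloxy (a 1.8-fold lower number from compound 3 to compound 4 (0.26 log units; within the scatter)) and butoxy (a 1.7-fold higher number from compound 2 to compound 4 (0.22 log units; within the scatter)). Among these compounds, the hexyl pair gives the first reading of sulfur in place of oxygen at this position, and with this chain the exchange yields a step within the scatter. Compound 4 also carries the longer chain yet stays within the scatter of compound 2, so the separation printed between the two ethers does not appear between compound 4 and compound 2, and no measurement offered here accounts for any of these readings.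

The compounds shown leave open how a butylsulfanyl chain would read on this carbon. They also leave open whether a much shorter group, such as methoxy, or a primary amine or a carboxylic acid, would hold the number in this range.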